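Dropping One Methoxy Group from a Nitrofuran Hydrazide

The compounds below may be only part of what the source reports. "The series", "measured", "known", "first", "only" and "open" are said of these compounds alone.

In a functional assay on NCI-H460 cells (Homo sapiens) for inhibition, read by sulforhodamine B assay, with a stated time of 48 h (on this read-out higher numbers stand for weaker inhibition of growth and lower numbers for stronger inhibition of growth), compound 1 `COc1ccc(C(=O)NNC(=O)c2ccc3[nH]c(-c4ccc([N+](=O)[O-])o4)nc3c2)cc1OC` gives 15.6 ug/mL, the lowest of the three numbers recorded. Compound 3 `COc1cc(C(=O)NNC(=O)c2ccc3[nH]c(-c4ccc([N+](=O)[O-])o4)nc3c2)cc(OC)c1OC` gives 31.3 ug/mL, which stays within the scatter of compound 1, while compound 2 `COc1cccc(C(=O)NNC(=O)c2ccc3[nH]c(-c4ccc([N+](=O)[O-])s4)nc3c2)c1` gives 62.5 ug/mL, a higher number beyond the scatter. Compound 4 `COc1cccc(C(=O)NNC(=O)c2ccc3[nH]c(-c4ccc([N+](=O)[O-])o4)nc3c2)c1` differs from compound 1 by hydrogen in place of methoxy on an aromatic carbon. For the measured compounds named here, the only measured step that touches this ring, a 2.0-fold higher number from compound 1 to compound 3 (0.30 log units; within the scatter), shows that gaining a methoxy there changes little, so losing one is also expected to move the number little, if at all. Compound 2 carries the same 3-methoxyphenyl but differs elsewhere, so its number cannot be assigned to that group alone. Compound 4 is therefore estimated at 25 ug/mL, between 10 ug/mL and 62 ug/mL, an expected step of a 1.6-fold higher number from compound 1 to compound 4 (0.20 log units; within the scatter).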

Compound 4, concentration for 50% growth inhibition: 62.5 ug/mL
Estimate against measurement, compound 4: 2.5-fold (0.40 log units) below; measured number above the stated range.
By their numbers in this assay, from the lowest: compounds 1, 3, 2 and 4 (each within the scatter of the next, the first and the last beyond it).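

Going from 3,4-dimethoxyphenyl to 3-methoxyphenyl is not a neutral change in this assay: hydrogen in place of methoxy gives a 4.0-fold higher number from compound 1 to compound 4 (0.60 log units; beyond the scatter), so this position responds to losing a methoxy in a way the earlier step, a 2.0-fold higher number from compound 1 to compound 3 (0.30 log units; within the scatter), did not reveal. With the 3-methoxyphenyl held fixed, exchanging the ring that carries the nitro group gives no change at the digits printed from compound 2 to compound 4 (within the scatter), so that exchange does not account for the high number of compound 2. From the compounds shown here alone, whether a hydroxyl group or an amine at this position would match methoxy or hydrogen remains open. Nothing available here explains the effect of this methoxy group.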